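The source may hold more compounds than are shown below. What is called first, only, known or untested is meant among the compounds shown, and "the series" means these compounds.

In an assay on cells for displacement of a labelled ligand from Orexin/Hypocretin receptor type 1 (Homo sapiens), read by scintillation counting, with stated times of 10 min and 90 min, tested at 10 uM (a lower number here means less inhibition, a higher number more inhibition at the concentration tested (going by the name of the read-out)), compound 1 `COC(=O)c1ccc2ccc(C(=O)c3ccc(C(F)(F)F)cc3)c-2cc1` gives -60.5%. Compound 2 `O=C(O)c1ccc2ccc(C(=O)c3ccc(C(F)(F)F)cc3)c-2cc1` carries one change relative to compound 1: hydrogen in place of methyl on an oxygen next to a carbonyl group. In this assay compound 2 gives -81.5%, so the step is a number 21 percentage points lower from compound 1 to compound 2 (beyond the scatter). Compound 3 `COC(=O)c1ccc2c(C(=O)c3ccccc3)cc(C(=O)c3ccccc3)c-2cc1` rests on a different core; how the two cores differ is not broken down here. In this assay compound 3 gives -10.6%, the highest of the three numbers and beyond the scatter from both others. Compound 4 `O=C(O)c1ccc2c(C(=O)c3ccccc3)cc(C(=O)c3ccccc3)c-2cc1` has not yet been measured and differs from compound 3 by hydrogen in place of methyl on an oxygen next to a carbonyl group, the same change as that between compound 1 and compound 2, at a place described in the same words. Within the data shown here, only one example of this change exists among the measured compounds, and the two cores are not alike, so the expectation rests on that single example. The step is expected to be a number 19.4 percentage points lower from compound 3 to compound 4 (beyond the scatter) because the same change gave a number 21 percentage points lower from compound 1 to compound 2 (beyond the scatter). In this assay compound 4 is therefore expected to give about -30%, within a range from -60% to 0% that allows for the different core.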

Compound 4, a percentage reported as inhibition, at one concentration (the size of the read-out at that concentration, not a potency): -10.4%
Beside the measured number, compound 4's estimate is 19.6 percentage points below it, and the stated range covers the measured number.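

In this assay, the change from methoxycarbonyl to carboxy gave a number 0.2 percentage points higher from compound 3 to compound 4 (within the scatter), so on this core the methyl ester and the acid cannot be told apart. Set beside the earlier step, the same change did not carry over from one core to the other: the same change on two cores in this assay, a number 21 percentage points lower (beyond the scatter) from compound 1 to compound 2 and a number 0.2 percentage points higher (within the scatter) from compound 3 to compound 4, 21.2 percentage points apart, beyond the scatter of two such steps. Among these compounds, this shows that the step seen on the core of compound 1 is no reliable guide to the step on the core of compound 3, but with only two pairs it does not show which feature of the cores sets them apart or what the change would do on a third core.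

The compounds shown leave open whether an amide or a nitrile in place of the carboxy group would also behave differently on the two cores. It also remains open whether the trifluoromethyl group, carried by compound 1 and compound 2 but absent from compound 3 and compound 4, plays any part, as no pair shown isolates it.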